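From a Methyl to a Chlorine on the Benzyl Ring

The compounds below may be only part of what the source reports. "The series", "measured", "known", "first", "only" and "open" are said of these compounds alone.

Compound 1, `Clc1ccc(COc2ccc(/C=C/C(/C=C/c3ccccn3)=N/Oc3ncnc4ccccc34)cc2)cc1`: 91.2%
Compound 2, `Cc1cccc(COc2ccc(/C=C/C(/C=C/c3ccccn3)=N/Oc3ncnc4ccccc34)cc2)c1`: 69.2%

Of the compounds shown here, two have been measured in a functional assay on SMMC-7721 cells (Homo sapiens) for inhibition, read by MTT assay, with a stated time of 72 h, tested at 1 uM; a lower number here means a weaker effect, a higher number a stronger effect of the compound at the concentration tested. Going by the values given here, compound 1 gives 91.2%, while compound 2 gives 69.2%, which is the lower of the two numbers; the only step recorded, a number 22 percentage points lower from compound 1 to compound 2 (beyond the scatter), separates them by more than the scatter.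

Compound 3, `Clc1ccccc1COc1ccc(/C=C/C(/C=C/c2ccccn2)=N/Oc2ncnc3ccccc23)cc1`, has not yet been measured in this assay. It differs from compound 2 in one place: 2-chlorophenyl in place of 3-methylphenyl on a saturated chain carbon bound to an oxygen on an aromatic ring.

Among the compounds with values here, the only step that bears on this change is a number 22 percentage points lower from compound 1 to compound 2 (beyond the scatter), which shows that exchanging a chlorophenyl for a methylphenyl in this position was followed by a modest loss. Within the data shown here, compound 3 returns a chlorophenyl, though with the chlorine at a different ring position than in compound 1, so no measured pair shows exactly this exchange. Compound 3 is therefore expected to recover part of that loss, with an estimated step of a number 10.8 percentage points higher from compound 2 to compound 3 (beyond the scatter) in this assay. The estimate for compound 3 is 80%, with a range from 62% to 94%.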

Compound 3, a percentage reported as inhibition, at one concentration (the size of the read-out at that concentration, not a potency): 10.1%
For compound 3 the middle estimate is 69.9 percentage points above the measured one, and the stated range ends above it.
By their numbers in this assay, from the lowest: compound 3; then compound 2; then compound 1.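

In this assay, replacing 4-chlorophenyl with 2-chlorophenyl on the saturated chain carbon bound to an oxygen on an aromatic ring gives a number 81.1 percentage points lower from compound 1 to compound 3 (beyond the scatter). These two groups have the same heavy-atom count and the same atoms, so the presence of a chlorine on this ring does not by itself secure a high number: where it sits on the ring matters here, which the earlier pair could not show because it changed both the substituent and its place. The second change, 2-chlorophenyl in place of 3-methylphenyl, gives a number 59.1 percentage points lower from compound 2 to compound 3 (beyond the scatter), so compound 2, with no chlorine, stands well above compound 3, and no information is available to explain why this ring is so sensitive to the change.

The three compounds leave open whether the low number belongs to chlorine in particular or would also follow with 2-methylphenyl or 2-fluorophenyl in the same place. They also leave open where 3-chlorophenyl or 4-methylphenyl would fall, the two groups that would separate the effect of the substituent from that of its place on the ring.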